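Replacing the Nitro Group of Compound 2 with a Longer Chain

A few compounds are considered here, and "the series" means these few. Any claim that something is new, unique, unknown or untested is made for them only; others in the source may bear on it.

Of the compounds shown here, three built on a shared core have been measured in an ADME assay on L6 cells (Rattus norvegicus) for cytotoxicity, read by resazurin assay, with a stated time of 72 h; a higher number here means a weaker inhibitor, a lower number a stronger inhibitor. Compound 1 `Cc1occc1C(=O)NC(=O)c1ccccc1O` gives 16 ug/mL. Compound 3 `O=C(NC(=O)c1ccccc1O)c1ccccc1O` gives 39 ug/mL. Compound 2 `O=C(NC(=O)c1ccccc1O)c1ccc([N+](=O)[O-])cc1` gives 53 ug/mL, the highest of the three numbers; its gap to compound 3 lies within the usual scatter, so the two cannot be ordered, while its gap to compound 1 lies beyond the scatter, so compound 2 is the weaker inhibitor of that pair.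

Compound 4 `COC(=O)CCC(=O)Nc1ccc(C(=O)NC(=O)c2ccccc2O)cc1` has not yet been measured. It differs from compound 2 in one place: ((2-(methoxycarbonyl)ethyl)carbonyl)amino in place of nitro on an aromatic carbon. Within the data shown here, no measured pair differs in this way, so nothing among the three numbers shows what this change does. The measured values cover only a modest range, and the expectation is that compound 4 stays near the weak end of it. The expected step of a 1.1-fold higher number from compound 2 to compound 4 (0.05 log units; within the scatter) is small, if anything toward a higher number, and within the scatter. Compound 4 is therefore estimated at 60 ug/mL, with a range from 25 ug/mL to 130 ug/mL.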

Compound 4, half-maximal inhibitory concentration: > 50 ug/mL
Compound 4: no number, only a limit (the forecaster's own chance of this, stated with the estimate: 20%); the middle value does not contradict the limit.
By their numbers in this assay, from the lowest: compound 1; then compounds 3 and 2 (each within the scatter of the next).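

In this assay, among these compounds, compound 4 gives > 50 ug/mL, which is a limit and not a number, so no step from compound 2 to compound 4 can be read. The compounds shown leave open what ((2-(methoxycarbonyl)ethyl)carbonyl)amino in place of nitro does in this assay.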